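A few compounds are considered here, and "the series" means these few. Any claim that something is new, unique, unknown or untested is made for them only; others in the source may bear on it.

Of the compounds shown here, three that share one core have been measured in an assay for binding affinity to metabotropic glutamate receptor 5 (Rattus norvegicus); on this read-out lower numbers stand for stronger inhibition and higher numbers for weaker inhibition. Compound 1 `Cc1ccccc1-c1cc(F)cc(-n2nnc(-c3ccccn3)n2)c1` gives 23 nM. Compound 2 `N#Cc1ccccc1-c1cc(F)cc(-n2nnc(-c3ccccn3)n2)c1` gives 4 nM. Compound 3 `Nc1ccccc1-c1cc(F)cc(-n2nnc(-c3ccccn3)n2)c1` gives 7 nM. On these numbers compound 3 stands second highest of the three: its nearest neighbour is compound 2, within the scatter of it, and its furthest is compound 1, beyond the scatter. Both steps that lie beyond the scatter start from compound 1: a 5.8-fold lower number from compound 1 to compound 2 (0.76 log units; beyond the scatter), and a 3.3-fold lower number from compound 1 to compound 3 (0.52 log units; beyond the scatter). The step of a 1.8-fold higher number from compound 2 to compound 3 (0.24 log units; within the scatter) lies within the scatter.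

Compound 4 `Fc1cc(-c2ccccn2)cc(-n2nnc(-c3ccccn3)n2)c1` has not yet been measured. Its change from compound 3 is pyridin-2-yl in place of 2-aminophenyl on an aromatic carbon: the 2-aminophenyl, with one hydrogen-bond donor, leaves, and pyridin-2-yl, with no hydrogen-bond donor and one hydrogen-bond acceptor, enters. For the measured compounds named here, no measured step swaps one ring for another; the measured steps only exchange a single group on the ring that leaves, and those exchanges moved this assay modestly at most. The step is therefore expected to be small, if beyond the scatter at all, leaning towards a slightly higher number. The number for compound 4 is estimated at 9 nM, with a range from 3 nM to 27 nM. This corresponds to an expected step of a 1.3-fold higher number from compound 3 to compound 4 (0.11 log units; within the scatter).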

Compound 4, inhibition constant: 95 nM
The estimate for compound 4 lay 11-fold (1.02 log units) below the measured number, and the stated range ends below it.
By their numbers in this assay, from the lowest: compounds 2 and 3 (each within the scatter of the next); then compound 1; then compound 4.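

Changing the whole ring at this position can move the number much further than the group changes on the phenyl ring did. In this assay, pyridin-2-yl in place of 2-aminophenyl gives a 14-fold higher number from compound 3 to compound 4 (1.13 log units; beyond the scatter) and pyridin-2-yl in place of 2-cyanophenyl gives a 24-fold higher number from compound 2 to compound 4 (1.38 log units; beyond the scatter), while the same ring in place of 2-methylphenyl gives the smaller 4.1-fold higher number from compound 1 to compound 4 (0.62 log units; beyond the scatter). So all three substituted phenyl rings give lower numbers than pyridin-2-yl, although the size of the gap depends strongly on which group the phenyl ring carries, and no available measurement explains this loss.

The change from a substituted phenyl ring to pyridin-2-yl does two things at once: it removes the group on the ring and it places a nitrogen in the ring, and these compounds cannot separate the two. An unsubstituted phenyl ring would address the first part, while pyridin-3-yl, or a pyridin-2-yl ring carrying a methyl or nitrile group, would show whether the position of the ring nitrogen or the missing group matters more.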